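Adding a Nitrile to Compound 3: What to Expect

A few compounds are considered here, and "the series" means these few. Any claim that something is new, unique, unknown or untested is made for them only; others in the source may bear on it.

Of the compounds shown here, three that share one core have been tested in a functional assay on A549 cells (Homo sapiens) for antiproliferative activity, read by MTT assay, with a stated time of 72 h; on this read-out higher numbers stand for weaker inhibition and lower numbers for stronger inhibition. Compound 1 `C=C(Cl)C(=O)Nc1cc(Nc2nccc(-c3cn(C)c4ccccc34)n2)c(OC)cc1N(C)CCN(C)C` gives 7520 nM in this assay. Compound 2 `COc1cc(N(C)CCN(C)C)c(NC(=O)C=C(C)C)cc1Nc1nccc(-c2cn(C)c3ccccc23)n1`, which carries a different group on the carbonyl carbon of the amide, gives 4100 nM in this assay. Compound 3 `CC/C=C\C(=O)Nc1cc(Nc2nccc(-c3cn(C)c4ccccc34)n2)c(OC)cc1N(C)CCN(C)C` gives 1530 nM in this assay, and it stands lowest of the three: the step of a 2.7-fold lower number from compound 2 to compound 3 (0.43 log units; beyond the scatter) and the step of a 4.9-fold lower number from compound 1 to compound 3 (0.69 log units; beyond the scatter) both lie beyond the scatter, whereas the step of a 1.8-fold lower number from compound 1 to compound 2 (0.26 log units; within the scatter) does not.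

Compound 4 `CC/C=C\C(=O)Nc1cc(Nc2ncc(C#N)c(-c3cn(C)c4ccccc34)n2)c(OC)cc1N(C)CCN(C)C` differs from compound 3 in one place: cyano in place of hydrogen on an aromatic carbon. Among the compounds with values here, every measured step so far changes only the group on the carbonyl carbon of the amide; none of them touches the six-membered aromatic ring with two nitrogens, so no measured step bears on this change, and nothing in the measured set points in either direction. The expected step of a 1.3-fold lower number from compound 3 to compound 4 (0.11 log units; within the scatter) in this assay is accordingly a small one, lying within the scatter. Compound 4 is therefore estimated at 1200 nM in this assay, with a range from 300 nM to 5000 nM that is kept wide to reflect the absence of any directly comparable step.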

Compound 4, half-maximal inhibitory concentration: 162 nM
Estimate against measurement, compound 4: 7.4-fold (0.87 log units) above; measured number outside the range, below it.
By their numbers in this assay, from the lowest: compound 4; then compound 3; then compounds 2 and 1 (each within the scatter of the next).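

In this assay, cyano in place of hydrogen on an aromatic carbon of the six-membered ring with two nitrogens gives a 9.4-fold lower number from compound 3 to compound 4 (0.98 log units; beyond the scatter), a step beyond the scatter. The earlier compounds shown here differed only in the group on the carbonyl carbon of the amide, so they said nothing about this ring; this step shows that the number also responds to a change far from the amide, at a carbon ortho to the 1-methyl-1H-indol-3-yl group and two atoms from the ring nitrogen. Nothing available here explains why this single change of two heavy atoms has such an effect.

The compounds shown leave open whether the effect belongs to cyano itself or whether other groups on the same carbon, such as an amine, a carboxylic acid or a trifluoromethyl group, would move the number in the same direction. Within the data shown here, they also leave open whether cyano would give a similar step alongside the 1-chloroethenyl or 2-methylprop-1-en-1-yl amides, since here it is seen only with the but-1-en-1-yl amide.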